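The source may report more compounds than this note shows. Statements on the series, on what has been measured and on what is new or still open speak of the compounds shown alone.

Working notes on the series, read in a functional assay on HeLa cells (Homo sapiens) for inhibition, read by sulforhodamine B assay, with a stated time of 74 h; a lower number here means a stronger inhibitor, a higher number a weaker inhibitor. Compound 1 (`O=C1C=CC2(C=C1)OCC(=O)N2S(=O)(=O)c1ccccc1`) gives > 10000 nM, which is a limit of the assay and not a number. Among the compounds with values here, compound 2 (`O=C1C=CC2(C=C1)OCC(=O)N2S(=O)(=O)c1ccc(N2CCCC2=O)cc1`) gives 880 nM, the only actual number so far in this assay. Within the data shown here, the single measured step is an at least 11-fold lower number from compound 1 to compound 2 (1.05 log units; beyond the scatter), and its size is a bound only, resting on (the limit of > 10000 nM in this assay, at which 1 of the 2 values shown sits).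

The next compound is compound 3 (`O=C1C=CC2(C=C1)OCC(=O)N2S(=O)(=O)c1ccc(C(F)(F)F)cc1`), which carries trifluoromethyl in place of 2-oxopyrrolidin-1-yl on an aromatic carbon. The measured step bears on this change only indirectly, since it introduced the group that compound 3 gives up. Compound 3 lacks the 2-oxopyrrolidin-1-yl that accompanied an at least 11-fold lower number from compound 1 to compound 2 (1.05 log units; beyond the scatter), so part of that large gain is expected to be lost, though how much cannot be read from one step. The expected change is moderate and towards a weaker inhibitor, at a 3.4-fold higher number from compound 2 to compound 3 (0.53 log units; beyond the scatter). For compound 3 the estimated value is 3000 nM, with an expected range of 800 nM to 10000 nM.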

Compound 3, half-maximal inhibitory concentration: 770 nM
Estimate against measurement, compound 3: 3.9-fold (0.59 log units) above, outside the stated range (below it).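

In this assay, the exchange gives a 1.1-fold lower number from compound 2 to compound 3 (0.06 log units; within the scatter), which shows that the gain at this aromatic carbon does not depend on the 2-oxopyrrolidin-1-yl itself: trifluoromethyl, with no ring and 0 hydrogen-bond acceptors, takes its place without a change beyond the scatter. Within the data shown here, measured against the unsubstituted parent, trifluoromethyl in place of hydrogen gives an at least 12-fold lower number from compound 1 to compound 3 (1.11 log units; beyond the scatter), so a second, quite different group at this place also produces a large step, where the earlier compounds offered only one such group. The value of compound 1 is a limit of the assay and not a number, and the size of this step, like that of the step to compound 2, is therefore a bound only: the limit of > 10000 nM in this assay, at which 1 of the 3 values shown sits.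

Still open, as far as these compounds go, is whether any group at this place gives the same result, or whether an amine, a carboxylic acid or a plain methyl would part from compound 2 and compound 3. Also open, from the compounds shown here alone, is how the trifluoromethyl would read at another carbon of the aromatic ring, and whether its effect carries over to changes in the shared core.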